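This account rests on a few compounds, and the source may have more. Where it says the series, first, only, none or still open, it means among the compounds named here.

Compound 1 `CC1(CC[C@H](c2ccc(C(=O)NCc3nn[nH]n3)cc2)N2C(=O)C(c3cc(Cl)cc(Cl)c3)=N[C@]23CC[C@@H](C(C)(C)C)CC3)CC1` is the reference point of this small set. In a functional assay on CHO cells for antagonist activity at Glucagon receptor (Homo sapiens), read by cAMP accumulation, with stated times of 30 min and 45 min (on this read-out lower numbers stand for stronger inhibition and higher numbers for weaker inhibition), compound 1 gives 100 nM, the lowest of the three numbers recorded. Compound 2 `CC(C)(C)CC[C@H](c1ccc(C(=O)NCc2nn[nH]n2)cc1)N1C(=O)C(c2cnccc2C(F)(F)F)=N[C@]12CC[C@@H](C(C)(C)C)CC2` gives 1200 nM in this assay, a gap beyond the usual scatter, and compound 3 `CC(C)(C)CC[C@H](c1ccc(C(=O)NCCS(=O)(=O)O)cc1)N1C(=O)C(c2cc(Cl)cc(Cl)c2)=N[C@]12CC[C@@H](C(C)(C)C)CC2` gives 8500 nM, the furthest from compound 1. The unmeasured compound 4 `CC(C)CC[C@H](c1ccc(C(=O)NCc2nn[nH]n2)cc1)N1C(=O)C(c2cc(Cl)cc(Cl)c2)=N[C@]12CC[C@@H](C(C)(C)C)CC2` differs from compound 1 in one place: isopropyl in place of 1-methylcyclopropyl on a saturated chain carbon, three bonds along the chain from an amide-type nitrogen in a ring and an aromatic carbon. Among the compounds with values here, no measured pair shows this change, so the direction is open; the expected step from compound 1 to compound 4 is a 2.0-fold higher number from compound 1 to compound 4 (0.30 log units; within the scatter), a modest loss that may well stay within the scatter. Compound 4 is therefore estimated at 200 nM, with a range from 70 nM to 600 nM.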

Compound 4, half-maximal inhibitory concentration: 150 nM
Compound 4: the middle estimate sits 1.3-fold (0.12 log units) above what was measured, within the range that was stated.
By their numbers in this assay, from the lowest: compounds 1 and 4 (each within the scatter of the next); then compound 2; then compound 3.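

Isopropyl in place of 1-methylcyclopropyl on this saturated chain carbon gives, in this assay, a 1.5-fold higher number from compound 1 to compound 4 (0.18 log units; within the scatter), the first direct reading at this position. In this pair, therefore, the three-membered ring and its extra carbon can be lost without the number moving beyond the scatter. Nothing shown explains this result.

The compounds shown leave open how an amine, a carboxylic acid or a phenyl group would read at this place. They also leave open whether the same exchange gives a similar step with the pyridine-bearing trifluoromethyl part of compound 2 in place of the dichlorophenyl group.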